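The compounds below may be only part of what the source reports. "The series", "measured", "known", "first", "only" and "open" are said of these compounds alone.

Measured compounds:
Compound 1 `COc1ccc(NC(=S)NC2CC(C)(C)Oc3ccc(Br)cc32)cc1`: 40000 nM
Compound 2 `CC1(C)CC(NC(=S)Nc2ccc([N+](=O)[O-])cc2)c2cc(Br)ccc2O1`: 9000 nM
Compound 3 `O=[N+]([O-])c1cccc(NC(=S)NC2CCOc3ccc(Cl)cc32)c1`: 8000 nM

In a functional assay on U-373MG ATCC cells (Homo sapiens) for inhibition, read by MTT assay, with a stated time of 72 h (on this read-out higher numbers stand for weaker inhibition and lower numbers for stronger inhibition), compound 1 gives 40000 nM, the highest of the three numbers. Compound 4 `CC1(C)CC(NC(=S)Nc2ccccc2Cl)c2cc(Br)ccc2O1`, not yet measured, keeps the core of compound 1 and exchanges one group: 2-chlorophenyl in place of 4-methoxyphenyl on an amide-type nitrogen. In words, 2-chlorophenyl stands in place of 4-methoxyphenyl on an amide-type nitrogen.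

Among the compounds with values here, the only measured step that bears on this change is a 4.4-fold lower number from compound 1 to compound 2 (0.65 log units; beyond the scatter), a modest one beyond the scatter, with nitro in place of methoxy on an aromatic carbon. Within the data shown here, compound 3 has a different core, so it offers no matching step. Among the measured compounds shown here, no measured compound carries 2-chlorophenyl, which makes the single step a loose guide. A modest move towards a lower number is therefore expected, though no change beyond the scatter remains possible. The expected step is a 2.7-fold lower number from compound 1 to compound 4 (0.43 log units; beyond the scatter). The estimate for compound 4 is 15000 nM, with an expected range from 5000 nM to 40000 nM.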

Compound 4, half-maximal inhibitory concentration: 34000 nM
Estimate against measurement, compound 4: 2.3-fold (0.36 log units) below; measured number inside the range.
By their numbers in this assay, from the lowest: compounds 3 and 2 (each within the scatter of the next); then compounds 4 and 1 (each within the scatter of the next).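

The exchange of 4-methoxyphenyl for 2-chlorophenyl on the amide-type nitrogen gives a 1.2-fold lower number from compound 1 to compound 4 (0.07 log units; within the scatter) in this assay. This differs from the earlier exchange at the same aryl group, a 4.4-fold lower number from compound 1 to compound 2 (0.65 log units; beyond the scatter), so among compounds 1, 2 and 4 a replacement there does not always shift the number beyond the scatter, and compound 4 goes against any general rule that replacing the methoxy-bearing ring lowers it. No measurement presented here accounts for the difference between these two exchanges.

The compounds shown leave open whether 4-chlorophenyl or 2-nitrophenyl on this nitrogen would behave like compound 4 or like compound 2. They also leave open how an aminophenyl or a carboxyphenyl group would read there.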